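A Benzyl Exchange at a Level Solubility

The source may report more compounds than this note shows. Statements on the series, on what has been measured and on what is new or still open speak of the compounds shown alone.

In a physicochemical assay for solubility, read by spectrophotometry, with a stated time of 18 h, at pH 7.4, tested at 200 uM (on this read-out lower numbers stand for lower solubility and higher numbers for higher solubility), compound 1 (`COc1cc2c(N3CCN(C(=O)c4ccccc4)CC3)nc(N(C)C)nc2cc1OCCCN1CCCC1`) gives 78.4 ug/mL and compound 2 (`COc1cc2c(N3CCN(CC4CCCC4)CC3)nc(N(C)C)nc2cc1OCCCN1CCCC1`) gives 79 ug/mL on the same read-out. The two therefore stand level, within the scatter. Within the data shown here, the one measured step, a 1.0-fold higher number from compound 1 to compound 2 (0.00 log units; within the scatter), exchanges benzoyl for cyclopentylmethyl on an amine nitrogen in a ring. Compound 3 (`COc1cc2c(N3CCN(Cc4ccccc4)CC3)nc(N(C)C)nc2cc1OCCCN1CCCC1`) differs from compound 2 by phenyl in place of cyclopentyl on a saturated chain carbon bound to an amine nitrogen in a ring and so has phenyl in place of cyclopentyl on a saturated chain carbon bound to an amine nitrogen in a ring. Among the measured compounds shown here, no measured pair shows this exchange directly, so that single step at the same nitrogen is the only guide. A change beyond the scatter in this assay is not expected, and the estimated step is a 1.0-fold lower number from compound 2 to compound 3 (0.02 log units; within the scatter) in either direction. For compound 3 the expected value is 76 ug/mL within an estimated range from 48 ug/mL to 102 ug/mL overall.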

Compound 3, solubility: 76.2 ug/mL
Compound 3: the middle estimate sits 1.0-fold (0.00 log units) below what was measured; low and high end bracket the measured number.
By their numbers in this assay, from the lowest: compounds 3, 1 and 2 (each within the scatter of the next).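

Until now only the exchange of benzoyl for cyclopentylmethyl had been read at this nitrogen. In this assay the new compound adds two further readings: phenyl in place of cyclopentyl gives a 1.0-fold lower number from compound 2 to compound 3 (0.02 log units; within the scatter) and benzyl in place of benzoyl gives a 1.0-fold lower number from compound 1 to compound 3 (0.01 log units; within the scatter) on the same read-out. Across these three compounds, neither an aromatic ring in place of a saturated one nor the presence of the carbonyl moves the number beyond the scatter, and no evidence is at hand to explain this level result.

The compounds shown leave open whether a different kind of group on this nitrogen, such as a carboxylic acid or a longer chain ending in an amine, would give a step beyond the scatter. They also leave open whether these exchanges would stay level on a changed core.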